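Three limits and a fourth compound expected alongside

The source may hold more compounds than are shown below. What is called first, only, known or untested is meant among the compounds shown, and "the series" means these compounds.

The measurements come from a functional assay on SNB-19 cells (Homo sapiens) for inhibition, read by sulforhodamine B assay, with a stated time of 48 h; a higher number here means that more compound is tolerated, a lower number that less compound is tolerated. Compound 3 `COc1cc(-c2nn(-c3cccc(NC(=O)c4cccc(C(F)(F)F)c4)c3)cc2-c2ccncc2)ccc1Cl` gives > 50000 nM there, and this is a limit of the measurement rather than a number. Compound 1 `O=C(Nc1cccc(-n2cc(-c3ccncc3)c(-c3ccc(Cl)c(O)c3)n2)c1)Nc1cccc(C(F)(F)F)c1` gives > 32500 nM in this assay, again a limit. Compound 2 `COc1cc(-c2nn(-c3cccc(NC(=O)Nc4cc(C(F)(F)F)cc(C(F)(F)F)c4)c3)cc2-c2ccncc2)ccc1Cl` gives > 50000 nM in this assay, once more a limit. Because the limit of > 50000 nM in this assay, at which 2 of the 3 values shown sit, and the limit of > 32500 nM in this assay, at which 1 of the 3 values shown sits, are all that the three results show, compound 3 cannot be placed above or below its neighbours: every value sits at the edge of what was tested, so no order among them can be read.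

Compound 4 `COc1cc(-c2nn(-c3cccc(NC(=O)Nc4ccc(Cl)c(Cl)c4)c3)cc2-c2ccncc2)ccc1Cl` has not yet been measured. It differs from compound 3 in one place: (3,4-dichlorophenyl)amino in place of 3-(trifluoromethyl)phenyl on a carbonyl carbon. Within the data shown here, no measured pair in this set shows the size of such a change. The expectation for compound 4 rests on compound 2, whose result in this assay is > 50000 nM. On that basis the step from compound 3 to compound 4 is expected to be a number no higher from compound 3 to compound 4 (the limit leaves the size open), nothing beyond the scatter. Compound 4 is estimated at 50000 nM, within a range from 20000 nM to 120000 nM, and most likely the result will again be reported only as a limit.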

Compound 4, concentration lethal to 50% of the cells: > 50000 nM
Compound 4 ended at the assay's limit; the forecaster's own chance of this, stated with the estimate: 80%; the middle value sits exactly at the limit.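

In this assay compound 3 gives > 50000 nM, a limit and not a number. Among these compounds, compound 4 gives > 50000 nM, also a limit, so no step between the two can be read. The compounds shown leave open the actual lethal concentration of each one, and whether this change on a carbonyl carbon alters it at all.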